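Methyl to methoxy on the shared core: four compounds

The source may hold more compounds than are shown below. What is called first, only, known or untested is meant among the compounds shown, and "the series" means these compounds.

Measured compounds:
compound 1 `Cc1ccc(C(=O)/C=C/c2cc(Br)cc(Br)c2Oc2c([N+](=O)[O-])cc(C(F)(F)F)cc2[N+](=O)[O-])cc1` — 10.1 ug/mL
compound 2 `Cc1ccc(C(=O)/C=C/c2cc(Cl)cc(Cl)c2Oc2c([N+](=O)[O-])cc(C(F)(F)F)cc2[N+](=O)[O-])cc1` — 10.1 ug/mL
compound 3 `COc1ccc(C(=O)/C=C/c2cc(Br)cc(Br)c2Oc2c([N+](=O)[O-])cc(C(F)(F)F)cc2[N+](=O)[O-])cc1` — 13.2 ug/mL

All three were read in a functional assay on A549 cells (Homo sapiens) for antiproliferative activity, read by MTT assay, with a stated time of 48 h; on this read-out lower numbers stand for stronger inhibition and higher numbers for weaker inhibition. Compound 2 and compound 1 give the same number to the digits reported, and the gap from either of them to compound 3 is within the usual scatter, so the three numbers are treated as one cluster for now. The cores of compound 1 and compound 2 differ in the halogen pair on the ring that carries the ether; that difference is not broken down here, and the two values show only that it leaves the read-out where it was.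

One change is seen once so far, (methoxy in place of methyl on an aromatic carbon), and it made the step of a 1.3-fold higher number from compound 1 to compound 3 (0.12 log units; within the scatter). Compound 4 `COc1ccc(C(=O)/C=C/c2cc(Cl)cc(Cl)c2Oc2c([N+](=O)[O-])cc(C(F)(F)F)cc2[N+](=O)[O-])cc1` is the partner of compound 2 under the same change, (methoxy in place of methyl on an aromatic carbon). The place of the change is described in the same words for both pairs, so it is taken as the same change, now on the core of compound 2.

Expectation for compound 4: since compound 2 sits where compound 1 sits, the step of a 1.3-fold higher number from compound 2 to compound 4 (0.11 log units; within the scatter) is expected to repeat the earlier one, resting on the single measured pair, compound 1 to compound 3. On that basis compound 4 is estimated at 13 ug/mL, within 7 ug/mL to 25 ug/mL, with no number expected to fall outside the range that the three measured compounds already span by more than the scatter.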

Compound 4, half-maximal inhibitory concentration: 12.6 ug/mL
For compound 4 the middle estimate is 1.0-fold (0.01 log units) above the measured one; the measured number falls inside the stated range.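

In this assay, methoxy in place of methyl on an aromatic carbon, para to a large group, gives a 1.2-fold higher number from compound 2 to compound 4 (0.10 log units; within the scatter), and this step on the core of compound 2 can be set beside the one on the core of compound 1: the same change on two cores in this assay, a 1.3-fold higher number (0.12 log units; within the scatter) from compound 1 to compound 3 and a 1.2-fold higher number (0.10 log units; within the scatter) from compound 2 to compound 4, 1.0-fold (0.02 log units) apart, within the scatter of two such steps. So within this pair of cores, which differ in their halogen pair, the change carries over with no visible difference, and the step seen on one core describes the step on the other about as well as repeated measurement allows. This does not show that a change of real size would carry over, as both steps lie within the scatter and the agreement is between two small steps, nor does it reach beyond these two cores or this cell line.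

The compounds shown leave open how the read-out responds to a group of another kind at the same place, such as an amine, a carboxylic acid or a longer chain like ethoxy in place of the methoxy. Also open, going by these compounds, is whether the same change still makes so small a step on a core where the trifluoromethyl or a nitro group gives way to a nitrile.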